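This account rests on a few compounds, and the source may have more. Where it says the series, first, only, none or still open, it means among the compounds named here.

Compound 2 `O=C1N=C(N2CCC[C@H]2C(=O)Nc2ccc3ncnc(Nc4cccc(Cl)c4)c3c2)S/C1=C/c1ccccc1[N+](=O)[O-]` is the point of departure for this step. In a functional assay on A549 cells (Homo sapiens) for antiproliferative activity, read by MTT assay (a higher number here means a weaker inhibitor, a lower number a stronger inhibitor), compound 2 gives only a limit, > 50000 nM, and not a number. For the measured compounds named here, its one measured relative is compound 1 `O=C1N=C(N2CCC[C@H]2C(=O)Nc2ccc3ncnc(Nc4cccc(Cl)c4)c3c2)S/C1=C/c1cccc(Cl)c1`, which carries 3-chlorophenyl where compound 2 carries 2-nitrophenyl. In this assay compound 1 likewise gives a limit, > 50000 nM. Going by the values given here, the single measured step, a step that the two limits leave unreadable from compound 1 to compound 2, therefore cannot be read in size or direction, because of the limit of > 50000 nM in this assay, at which 2 of the 2 values shown sit. The new compound 3 `O=C1N=C(N2CCC[C@H]2C(=O)Nc2ccc3ncnc(Nc4cccc(Cl)c4)c3c2)S/C1=C/c1ccccc1F` differs from compound 2 in one place: fluoro in place of nitro on an aromatic carbon. No measured step touches this particular change, and the one step that exists gives neither size nor direction, so there is no ground in the numbers shown to expect compound 3 to move beyond the usual scatter in either direction in this assay. Compound 3 is thus expected to sit near 50000 nM, with a range from 10000 nM to 100000 nM, and will most probably again be reported only as a limit. The step of a number no higher from compound 2 to compound 3 (the limit leaves the size open) is accordingly estimated as no change beyond the scatter.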

Compound 3, half-maximal inhibitory concentration: 34500 nM
Compound 3: middle estimate off by 1.4-fold (0.16 log units), on the high side; the range from low to high includes it.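

In this assay compound 3 alone of the three gives a number and not a limit, so the aromatic carbon that carries nitro in compound 2 and fluoro in compound 3 can now be tied to a readable value. Fluoro in place of nitro gives an at least 1.4-fold lower number from compound 2 to compound 3 (0.16 log units; that floor lies within the scatter), and 2-fluorophenyl in place of 3-chlorophenyl gives an at least 1.4-fold lower number from compound 1 to compound 3 (0.16 log units; that floor lies within the scatter); each is only a floor, so neither step is shown to reach beyond the scatter. The true size of both steps stays unknown because the other two compounds remain at the limit of the assay: the limit of > 50000 nM in this assay, at which 2 of the 3 values shown sit.

As far as these compounds go, whether an amine or a methoxy group on this aromatic carbon would give a number clearly lower than that of compound 3 remains open. Also open, from the compounds shown here alone, is what fluoro on another carbon of this ring would give, and the step between the two compounds held at the limit still cannot be read.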